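Replacing the ester side chain of compound 2

The source may report more compounds than this note shows. Statements on the series, on what has been measured and on what is new or still open speak of the compounds shown alone.

In a functional assay on SGC-7901 cells (Homo sapiens) for cytotoxicity, read by sulforhodamine B assay, with a stated time of 72 h (on this read-out higher numbers stand for weaker inhibition and lower numbers for stronger inhibition), compound 1 `C=C1C(=O)O[C@@H]2CC(C)=C([C@@H](C)CCCOC(C)=O)[C@@H](OC(=O)CN3CCCCC3)[C@H]12` gives 11500 nM, compound 2 `C=C1C(=O)O[C@@H]2CC(C)=C([C@@H](C)CCCOC(C)=O)[C@@H](OC(=O)COc3ccc(C(C)=O)cc3)[C@H]12` gives 49600 nM and compound 3 `C=C1C(=O)O[C@@H]2CC(C)=C([C@@H](C)CCCOC(C)=O)[C@@H](OC(=O)COc3ccc(C(=O)OCCC)cc3)[C@H]12` gives 27700 nM. Compound 2 thus sits at the upper end of these numbers: a 1.8-fold lower number from compound 2 to compound 3 (0.25 log units; within the scatter) stays within the scatter, whereas a 4.3-fold higher number from compound 1 to compound 2 (0.63 log units; beyond the scatter) goes beyond it. Compound 4 `C=C1C(=O)O[C@@H]2CC(C)=C([C@@H](C)CCCOC(C)=O)[C@@H](OC(=O)c3cccc(F)c3)[C@H]12` carries 3-fluorophenyl in place of (4-acetylphenoxy)methyl on a carbonyl carbon. Among the measured compounds shown here, only the modest step from compound 1 alters that same side chain, and no measured compound contains 3-fluorophenyl. A step of similar or smaller size is therefore expected, toward the value of compound 3, 27700 nM. The expected change is a 1.8-fold lower number from compound 2 to compound 4 (0.26 log units; within the scatter). For compound 4 the estimated value is 27000 nM, with an expected range of 9000 nM to 75000 nM.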

Compound 4, half-maximal inhibitory concentration: 12900 nM
Compound 4: middle estimate off by 2.1-fold (0.32 log units), on the high side; low and high end bracket the measured number.
By their numbers in this assay, from the lowest: compounds 1 and 4 (each within the scatter of the next); then compounds 3 and 2 (each within the scatter of the next).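

In this assay, 3-fluorophenyl in place of (4-acetylphenoxy)methyl on this carbonyl carbon gives a 3.8-fold lower number from compound 2 to compound 4 (0.58 log units; beyond the scatter), so the number here can shift even when the entering and leaving groups both hold a six-membered aromatic ring. Against the side chain with the piperidine ring, the same group gives a 1.1-fold higher number from compound 1 to compound 4 (0.05 log units; within the scatter), so these two different side chains cannot be told apart in this read-out. No available evidence accounts for either step. 

The compounds shown leave open what plain phenyl, without the fluorine, would give on this carbonyl carbon. They also leave open how a carboxylic acid or a longer chain would read there.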